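Methoxypyrimidine in place of methoxyphenyl on the thiazole core

The source may hold more compounds than are shown below. What is called first, only, known or untested is meant among the compounds shown, and "the series" means these compounds.

Compound 1 `C[C@@H]1CN(c2sc(C3CC3)nc2-c2nc3ccccc3[nH]2)CCN1C(=O)Cn1cnc2cccnc21` gives 745 nM in a functional assay on U2OS cells for antagonist activity at C-X-C chemokine receptor type 3 (Homo sapiens), read by beta-arrestin recruitment; on this read-out lower numbers stand for stronger inhibition and higher numbers for weaker inhibition.
Compound 2 `C[C@@H]1CN(c2sc(CO)nc2-c2nc3ccccc3[nH]2)CCN1C(=O)Cn1cnc2cccnc21` reaches only the limit of > 10000 nM in this assay.
Compound 3 `COc1ccc(-c2nc(C(F)(F)F)sc2N2CCN(C(=O)Cn3cnc4cccnc43)[C@H](C)C2)cc1` gives 131 nM in this assay.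

Within the data shown here, compound 3 holds the lowest of the two numbers given, with compound 1 an at least 13-fold higher number from compound 1 to compound 2 (1.12 log units; beyond the scatter) further away in the only measured step, which concerns a different position of the core. Compound 3 and compound 1 differ in several places at once, so no single step can be read from that pair. Compound 4 `COc1ncc(-c2nc(C(F)(F)F)sc2N2CCN(C(=O)Cn3cnc4cccnc43)[C@H](C)C2)cn1` has not yet been measured. It differs from compound 3 in one place: 2-methoxypyrimidin-5-yl in place of 4-methoxyphenyl on an aromatic carbon. Among the measured compounds shown here, no measured step touches this position, so the measured step from compound 1 to compound 2 bears on it only in showing that the core can shift a long way when a group on it is exchanged. Compound 4 is therefore expected to sit somewhat above compound 3, a step of a 2.3-fold higher number from compound 3 to compound 4 (0.36 log units; beyond the scatter), giving an estimated 300 nM with a range from 100 nM to 1000 nM in this assay.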

Compound 4, half-maximal inhibitory concentration: 177 nM
For compound 4 the middle estimate is 1.7-fold (0.23 log units) above the measured one; measured number inside the range.
By their numbers in this assay, from the lowest: compounds 3 and 4 (each within the scatter of the next); then compound 1. At a limit, above all of these: compound 2.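

In this assay, 2-methoxypyrimidin-5-yl in place of 4-methoxyphenyl gives a 1.4-fold higher number from compound 3 to compound 4 (0.13 log units; within the scatter), the first step read at this position, on the aromatic carbon next to the ring nitrogen. Here, then, a six-membered aromatic ring of carbon only and one with 2 hetero atoms cannot be told apart, with the methoxy group and the trifluoromethyl group kept in both compounds. No measurement shown here offers an explanation for this.

What the compounds leave open is whether a longer chain in place of the methoxy group, or an amine or a carboxylic acid on the six-membered ring, would also leave the number within the scatter. On these data alone, it also remains open whether the same exchange would read alike with cyclopropyl in place of the trifluoromethyl group.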